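The source may report more compounds than this note shows. Statements on the series, on what has been measured and on what is new or still open speak of the compounds shown alone.

Compound 3 `CC(C)[C@@H](NC(=O)c1cccc(C(=N)N)c1)C(=O)NCC1CCC(CN)CC1` gives the highest of the three numbers in an assay on isolated protein for binding affinity to serine protease 1 (Homo sapiens) (a higher number here means a weaker inhibitor, a lower number a stronger inhibitor), namely 16200 nM. Compound 1 `CSCC[C@@H](NC(=O)c1cccc(C(=N)N)c1)C(=O)NCC1CCC(CN)CC1` stands nearest to it with 10000 nM, and the step of a 1.6-fold higher number from compound 1 to compound 3 (0.21 log units; within the scatter) lies within the scatter. Compound 2 `CSCC[C@H](NC(=O)c1cccc(C(=N)N)c1)C(=O)NCC1CCC(CN)CC1` gives 7900 nM, and the step of a 1.3-fold lower number from compound 1 to compound 2 (0.10 log units; within the scatter) also lies within the scatter.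

Compound 4 `CC(C)[C@H](NC(=O)c1cccc(C(=N)N)c1)C(=O)NCC1CCC(CN)CC1` differs from compound 3 in one respect: the two compounds have the same atoms and bonds; at least one stereo element is drawn with a configuration in one of them and without one in the other: 1 of 4 stereo elements differ; a stereocentre at a saturated chain carbon is drawn R in compound 3 and S in compound 4. Among the measured compounds shown here, the only measured step that bears on this change is the inversion of the same stereocentre between compound 1 and compound 2, a 1.3-fold lower number from compound 1 to compound 2 (0.10 log units; within the scatter), which stayed within the scatter. No step beyond the scatter is therefore expected in this assay from compound 3 to compound 4, and the expected step is a 1.2-fold lower number from compound 3 to compound 4 (0.10 log units; within the scatter). Compound 4 is accordingly estimated at 13000 nM, with a range from 6000 nM to 30000 nM.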

Compound 4, inhibition constant: 12600 nM
Compound 4: middle estimate off by 1.0-fold (0.01 log units), on the high side, and the stated range covers the measured number.
By their numbers in this assay, from the lowest: compounds 2, 1, 4 and 3 (each within the scatter of the next, the first and the last beyond it).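

The inversion of the stereocentre now also reads on the isopropyl compounds, with a 1.3-fold lower number from compound 3 to compound 4 (0.11 log units; within the scatter), so in this assay neither side chain separates the R and S forms beyond the scatter. The change from 2-(methylsulfanyl)ethyl to isopropyl can now be read on the S form as well, giving a 1.6-fold higher number from compound 2 to compound 4 (0.20 log units; within the scatter). Its size holds across both configurations: the same change on two cores in this assay, a 1.6-fold higher number (0.21 log units; within the scatter) from compound 1 to compound 3 and a 1.6-fold higher number (0.20 log units; within the scatter) from compound 2 to compound 4, 1.0-fold (0.01 log units) apart, within the scatter of two such steps.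

Going by these compounds, what remains open is whether a carboxylic acid or an amine on this side chain would move the number beyond the scatter.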